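The compounds below may be only part of what the source reports. "The series", "measured", "known", "first", "only" and "open" are said of these compounds alone.

Measured compounds:
Compound 1, `CN(C[C@@H]1CCCc2cc(S(=O)(=O)c3cccc(F)c3)ccc21)S(N)(=O)=O`: in an assay on isolated protein for displacement of a labelled ligand from 5-hydroxytryptamine receptor 6 (Homo sapiens) (a higher number here means a weaker inhibitor, a lower number a stronger inhibitor), compound 1 gives 3.98 nM.
Compound 2, `NCC(=O)NC[C@@H]1CCCc2cc(S(=O)(=O)c3cccc(F)c3)ccc21`: in this assay compound 2 gives 0.316 nM.

Within the data shown here, compound 2 stands lowest of the two numbers; compound 1 is the only other measured compound, and the single step, a 13-fold lower number from compound 1 to compound 2 (1.10 log units; beyond the scatter), is beyond the scatter. Compound 3, `CN(C[C@@H]1CCCc2cc(S(=O)(=O)c3cccc(F)c3)ccc21)C(N)=O`, is not yet measured. Its difference from compound 2 is carbamoyl(methyl)amino in place of ((aminomethyl)carbonyl)amino on a saturated chain carbon bound to a saturated ring carbon. Among the measured compounds shown here, no measured step makes this exact change. The step of a 13-fold lower number from compound 1 to compound 2 (1.10 log units; beyond the scatter) is the only one that bears on it: it replaced methyl(sulfamoyl)amino with the ((aminomethyl)carbonyl)amino group that compound 3 now gives up, and the entering carbamoyl(methyl)amino, like the group in compound 1, contains a methyl. The expectation is therefore that compound 3 gives back part of that gain, a step of a 3.2-fold higher number from compound 2 to compound 3 (0.50 log units; beyond the scatter) in this assay toward a higher number. Compound 3 is estimated at 1 nM, within 0.3 nM to 4 nM.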

Compound 3, inhibition constant: 39.8 nM
The estimate for compound 3 lay 40-fold (1.60 log units) below the measured number; the whole stated range lies below it.
By their numbers in this assay, from the lowest: compound 2; then compound 1; then compound 3.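

In this assay, the groups leaving and entering on this saturated chain carbon hold the same heavy atoms, yet a 130-fold higher number from compound 2 to compound 3 (2.10 log units; beyond the scatter), so this position responds strongly to how those atoms are joined, not only to which atoms are present. With the methyl-bearing amine nitrogen kept, the exchange on that nitrogen also moves the number, as a 10-fold higher number from compound 1 to compound 3 (1.00 log units; beyond the scatter), which ranks sulfamoyl ahead of carbamoyl there. No measurement at hand accounts for either step.

The compounds shown do not separate the contribution of the methyl on the amine nitrogen from that of the terminal amine in compound 2. A urea without that methyl, or an acetamide lacking the terminal amine, would bear directly on this question.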